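The source may hold more compounds than are shown below. What is called first, only, known or untested is meant among the compounds shown, and "the series" means these compounds.

Among the measured compounds shown here, in an assay on CHO cells for displacement of a labelled ligand from adenosine receptor A1 (Homo sapiens), read by scintillation counting, with a stated time of 3 h (on this read-out higher numbers stand for weaker inhibition and lower numbers for stronger inhibition), compound 2 `CC(C)(C)Cn1cc2c(Cl)nc(NC(=O)c3ccccc3)nc2n1` gives 11000 nM, the only number among the two values shown. Compound 1 `Cn1cc2c(Cl)nc(NC(=O)c3ccccc3)nc2n1` reaches only the limit of this assay, > 100000 nM, which is a limit rather than a number. The second of the two values shown thus sits at the limit of > 100000 nM in this assay, at which 1 of the 2 values shown sits. For the measured compounds named here, the one measured step between the two is an at least 9.0-fold lower number from compound 1 to compound 2 (0.95 log units; beyond the scatter), at least modest in size and beyond the scatter.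

Compound 3 `CC(C)n1cc2c(Cl)nc(NC(=O)c3ccccc3)nc2n1` differs from compound 2 by isopropyl in place of neopentyl on an aromatic nitrogen. Going by the values given here, the only measured step that bears on this change is an at least 9.0-fold lower number from compound 1 to compound 2 (0.95 log units; beyond the scatter), in which a larger group on the chain carbon bound to the aromatic nitrogen went with the stronger binding. Here the group entering, isopropyl, is smaller than the neopentyl leaving, so a step back toward weaker binding is expected in this assay, though isopropyl still carries more than the hydrogen of compound 1, so the step should fall short of a return to the limit. Compound 3 is therefore estimated at 30000 nM, within 8000 nM to 100000 nM, a step of a 2.7-fold higher number from compound 2 to compound 3 (0.44 log units; beyond the scatter) expected.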

Compound 3, inhibition constant: 19600 nM
Estimate against measurement, compound 3: 1.5-fold (0.18 log units) above; low and high end bracket the measured number.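

In this assay, isopropyl in place of neopentyl on the aromatic nitrogen gives a 1.8-fold higher number from compound 2 to compound 3 (0.25 log units; within the scatter), so the two groups cannot be told apart on this read-out, and no order can be stated between the two compounds. Isopropyl in place of methyl on the same nitrogen gives an at least 5.1-fold lower number from compound 1 to compound 3 (0.70 log units; beyond the scatter), which shows that the gain over methyl is already present with isopropyl and that the larger neopentyl adds nothing beyond the scatter. Compound 1 stands at a limit and not at a number, so the full size of that step stays unknown: the limit of > 100000 nM in this assay, at which 1 of the 3 values shown sits.

The compounds shown leave open whether an ethyl or a cyclopentyl on this nitrogen would fall with compound 2 and compound 3 or nearer to compound 1, and whether a chain ending in an amine or a carboxylic acid would be tolerated there at all. They also leave open whether replacing the chlorine of the shared core with an amine would shift all of these numbers together or change how the nitrogen substituents rank.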